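The compounds below may be only part of what the source reports. "The series", "measured", "known", "first", "only" and "open" are said of these compounds alone.

Measured so far:
- compound 1 `CC(NC1=NS(=O)(=O)c2cccnc2N1)C(C)(C)C`: 7.5 uM
- compound 2 `CC(NC1=NS(=O)(=O)c2cnccc2N1)C(C)(C)C`: 154 uM

These two compounds were tested in a functional assay (aorta) with Rattus norvegicus as the target; on this read-out lower numbers stand for an effect already at smaller amounts and higher numbers for an effect only at larger amounts of compound. Compound 1 gives the lowest of the two numbers; compound 2 gives a number that lies far higher, well beyond the usual scatter, so compound 1 acts at clearly smaller amounts. Within the data shown here, no single-point step between these two is given, so their two values are simply set side by side.

Compound 3 `CC(NC1=NS(=O)(=O)c2cc(Cl)cnc2N1)C(C)(C)C` has not yet been measured. It differs from compound 1 in one place: chloro in place of hydrogen on an aromatic carbon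

Among the measured compounds shown here, since no measured step of this kind exists, the expectation rests on compound 1 alone. A change of this size, on the aromatic ring of the shared core, is expected to move the number only modestly; the step of a 1.9-fold lower number from compound 1 to compound 3 (0.27 log units; within the scatter) is expected to be small and, if anything, toward a lower number. Compound 3 is therefore estimated at 4 uM, within a range from 1 uM to 20 uM.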

Compound 3, concentration for half-maximal effect: 2.3 uM
Beside the measured number, compound 3's estimate is 1.7-fold (0.24 log units) above it; the measured number falls inside the stated range.
By their numbers in this assay, from the lowest: compound 3; then compound 1; then compound 2.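

In this assay, chloro in place of hydrogen on an aromatic carbon, two atoms from the ring nitrogen, gives a 3.3-fold lower number from compound 1 to compound 3 (0.51 log units; beyond the scatter) and so moves the number in the favourable direction. Among these compounds, this is the first single-place step in the set, and it shows that this ring carbon can carry a substituent without losing the effect; the lower number means that compound 3 acts at smaller amounts than compound 1. No measurement is available that would explain this step.

From the compounds shown here alone, it remains open whether the lower number is specific to chloro, or whether fluoro, bromo, methyl or methoxy on the same carbon would give a similar step. Going by these compounds, it is also open whether a larger or charged group there, such as an amine or a carboxylic acid, would keep the effect.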